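Adding a nitro group: from compound 3 to compound 4

This account rests on a few compounds, and the source may have more. Where it says the series, first, only, none or still open, it means among the compounds named here.

Compound 2 `COc1ccc(Oc2ccccc2-c2ccsc2S(=O)(=O)N2CCN(C(=O)Nc3ccc([N+](=O)[O-])cc3)CC2)cc1OC` and compound 1 `COc1ccc(Oc2ccc([N+](=O)[O-])cc2-c2ccsc2S(=O)(=O)N2CCN(C(=O)Nc3ccc([N+](=O)[O-])cc3)CC2)cc1OC` differ by nitro in place of hydrogen on an aromatic carbon. In a functional assay on RS4-11 cells (Homo sapiens) for inhibition, read by CCK-8 assay, with a stated time of 48 h (a higher number here means a weaker inhibitor, a lower number a stronger inhibitor), compound 2 gives > 50000 nM, which is a limit of the assay and not a number. Compound 1 gives > 50000 nM in this assay, again a limit. The step that the two limits leave unreadable from compound 2 to compound 1 cannot be read because of the limit of > 50000 nM in this assay, at which 2 of the 3 values shown sit.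

Compound 3 `O=S(=O)(c1sccc1-c1ccccc1Oc1ccc(O)c(O)c1)N1CCN(C(=S)Nc2cc(C(F)(F)F)cc(C(F)(F)F)c2)CC1` gives 7300 nM in this assay; how its core differs from that of compound 2 is not broken down here. Compound 4 `O=[N+]([O-])c1ccc(Oc2ccc(O)c(O)c2)c(-c2ccsc2S(=O)(=O)N2CCN(C(=S)Nc3cc(C(F)(F)F)cc(C(F)(F)F)c3)CC2)c1` is not yet measured and differs from compound 3 by nitro in place of hydrogen on an aromatic carbon. This is the same kind of change as from compound 2 to compound 1, but not the same: in compound 4 the entering group sits para to a 3,4-dihydroxyphenoxy group, in compound 1 para to a 3,4-dimethoxyphenoxy group. The earlier pair gives no readable size, so the expected step of a 1.0-fold lower number from compound 3 to compound 4 (0.02 log units; within the scatter) is taken as small. Compound 4 is expected to give 7000 nM in this assay, estimated between 2000 nM and 30000 nM.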

Compound 4, half-maximal inhibitory concentration: 9500 nM
For compound 4 the middle estimate is 1.4-fold (0.13 log units) below the measured one, within the range that was stated.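

In this assay, nitro in place of hydrogen gives a 1.3-fold higher number from compound 3 to compound 4 (0.11 log units; within the scatter), so on this core the change has no readable effect. Among the compounds shown here, whether that result carries to the other core stays unknown, because the step from compound 2 to compound 1 cannot be read: the limit of > 50000 nM in this assay, at which 2 of the 4 values shown sit. The single readable pair therefore sets no rule for the series, and it speaks only for nitro para to a 3,4-dihydroxyphenoxy group.

The compounds shown leave open whether an amine or a carboxylic acid on the same aromatic carbon would give a step beyond the scatter. They also give no readable size for any change on the core of compound 2.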